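The source may report more compounds than this note shows. Statements on the series, on what has been measured and on what is new or still open speak of the compounds shown alone.

Compound 2 `O=C(CCCCC(S)CCS)Nc1ccccc1` is an amide whose chain carries two thiol groups. Going by the values given here, in a functional assay on Bel-7402 cells (Homo sapiens) for inhibition, read by MTT assay, with a stated time of 24 h, tested at 10 ug/mL (on this read-out lower numbers stand for less inhibition of growth and higher numbers for more inhibition of growth at the one concentration tested), compound 2 gives 3.72%, the lower of the two numbers known so far; its only neighbour, compound 1 `O=C(CCCCC(S)CCS)NO`, gives 28.2% in this assay. Among the compounds with values here, the one measured step, a number 24.5 percentage points lower from compound 1 to compound 2 (beyond the scatter), came with phenyl in place of hydroxy on an amide-type nitrogen. Compound 3 `Cc1cccc(NC(=O)CCCCC(S)CCS)c1` has not yet been measured in this assay. It differs from compound 2 by methyl in place of hydrogen on an aromatic carbon. Within the data shown here, no measured step touches a change of this kind: the only step known alters the group on the amide-type nitrogen, not a hydrogen on an aromatic carbon, so it gives no guide to direction or size. The step expected is therefore a number 2.3 percentage points higher from compound 2 to compound 3 (within the scatter), within the scatter. Compound 3 is estimated to give 6% in this assay, most likely between 0% and 18%.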

Compound 3, percent growth inhibition at one concentration: 14.1%
The estimate for compound 3 lay 8.1 percentage points below the measured number, and the stated range covers the measured number.
By their numbers in this assay, from the lowest: compound 2; then compound 3; then compound 1.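

In this assay, methyl in place of hydrogen on an aromatic carbon, meta to a large group, gives a number 10.4 percentage points higher from compound 2 to compound 3 (beyond the scatter). The earlier step changed only the group on the amide-type nitrogen, whereas this one leaves that nitrogen's phenyl in place and shows that a single added carbon on the ring can move the number beyond the usual scatter. No measured information here accounts for this rise.

The compounds shown leave open whether the same ring carbon would respond similarly to another group, such as an amine, a carboxylic acid, chlorine or a longer chain like ethyl. They also leave open whether methyl would give a similar step on a different carbon of the ring, as only this one placement appears here.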